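A Methyl in Place of Chloro: Compound 1 to Compound 3

The compounds below may be only part of what the source reports. "The series", "measured", "known", "first", "only" and "open" are said of these compounds alone.

compound 1 `CCCC(Oc1ccc(-n2cc(Cl)cn2)cc1)c1ccc(C(=O)NCCC(=O)O)cc1`: 1100 nM
compound 2 `O=C(O)CCNC(=O)c1ccc(C(Oc2ccc(-n3cc(C(F)(F)F)cn3)cc2)C2CC2)cc1`: 1300 nM

Both were tested in an assay on cells for displacement of a labelled ligand from Glucagon receptor (Homo sapiens), in the presence of a further agent that is not named here; a higher number here means a weaker inhibitor, a lower number a stronger inhibitor. Compound 1 gives 1100 nM and compound 2 gives 1300 nM; the two numbers sit within the usual scatter of each other, so compound 1 does not stand apart from compound 2. Compound 3 `CCCC(Oc1ccc(-n2cc(C)cn2)cc1)c1ccc(C(=O)NCCC(=O)O)cc1` differs from compound 1 by methyl in place of chloro on an aromatic carbon. For the measured compounds named here, no step between measured compounds covers this change, so the expectation in this assay is a shift from compound 1 of no more than the scatter, if anything toward a weaker inhibitor. For compound 3 the estimate is 1500 nM, with a range from 700 nM to 3500 nM, the expected step being a 1.4-fold higher number from compound 1 to compound 3 (0.13 log units; within the scatter).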

Compound 3, inhibition constant: 1900 nM
Estimate against measurement, compound 3: 1.3-fold (0.10 log units) below, and the stated range covers the measured number.
By their numbers in this assay, from the lowest: compounds 1, 2 and 3 (each within the scatter of the next).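

In this assay, the change from 4-chloro-1H-pyrazol-1-yl to 4-methyl-1H-pyrazol-1-yl gives a comparison at this position in one place only, and the step is a 1.7-fold higher number from compound 1 to compound 3 (0.24 log units; within the scatter) for this change. At this position, then, methyl and chloro are not told apart in this assay. No measurement offered here bears on the reason for this result.

As far as these compounds go, whether a nitrile, an amine or a longer chain on this carbon would give a step beyond the scatter stays open. Compound 2 differs from compound 1 in more than one place, so the trifluoromethyl group cannot be judged at this position.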